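Hydroxyphenyl Analogue Expected from an Aminophenyl Precedent

The source may report more compounds than this note shows. Statements on the series, on what has been measured and on what is new or still open speak of the compounds shown alone.

Of the compounds shown here, three of one series have been measured in an assay (Rattus norvegicus) for inhibition of Fatty-acid amide hydrolase 1 (Homo sapiens); on this read-out lower numbers stand for stronger inhibition and higher numbers for weaker inhibition. Compound 1 `COC(=O)c1ccccc1-c1cnc(C(=O)CCCCCCc2ccccc2)o1` gives 60 nM. Compound 2 `O=C(CCCCCCc1ccccc1)c1ncc(-c2ccccc2F)o1` gives 110 nM, the highest of the three numbers. Compound 3 `Nc1cccc(-c2cnc(C(=O)CCCCCCc3ccccc3)o2)c1` gives 19 nM. The step of a 1.8-fold higher number from compound 1 to compound 2 (0.26 log units; within the scatter) stays within the scatter, whereas the step of a 5.8-fold lower number from compound 2 to compound 3 (0.76 log units; beyond the scatter) is a modest but real change toward stronger inhibition.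

Compound 4 `O=C(CCCCCCc1ccccc1)c1ncc(-c2cccc(O)c2)o1` has not yet been measured. It differs from compound 2 in one place: 3-hydroxyphenyl in place of 2-fluorophenyl on an aromatic carbon. Among the measured compounds shown here, the only measured step that bears on this change is the one from compound 2 to compound 3, where 3-aminophenyl replaced 2-fluorophenyl at the same place and brought a lower number beyond the scatter. Compound 4 carries a 3-hydroxyphenyl group, which, like the 3-aminophenyl of compound 3, brings one hydrogen-bond donor and one hydrogen-bond acceptor where compound 2 has none. For the measured compounds named here, since the only analogous step is the one from compound 2 to compound 3, a lower number in this assay is expected for compound 4, though the single precedent leaves the size uncertain. Compound 4 is therefore estimated at 30 nM, within a range from 12 nM to 80 nM. The expected step is a 3.7-fold lower number from compound 2 to compound 4 (0.56 log units; beyond the scatter).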

Compound 4, inhibition constant: 50 nM
Compound 4: the middle estimate sits 1.7-fold (0.22 log units) below what was measured; the measured number falls inside the stated range.
By their numbers in this assay, from the lowest: compound 3; then compounds 4, 1 and 2 (each within the scatter of the next, the first and the last beyond it).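

In this assay, among the compounds shown here, the aminophenyl group of compound 3 is no longer the only group at this place, next to the ring oxygen, that lowers the number relative to the 2-fluorophenyl group: the 3-hydroxyphenyl group also does so, with a 2.2-fold lower number from compound 2 to compound 4 (0.34 log units; beyond the scatter) as the step. The two groups are nevertheless not interchangeable, since hydroxy in place of amino on the same aromatic carbon gives a 2.6-fold higher number from compound 3 to compound 4 (0.42 log units; beyond the scatter) as its step, showing that having a hydrogen-bond donor and a hydrogen-bond acceptor in common does not by itself set the number. No evidence at hand accounts for the difference between the amino and hydroxy groups.

Both steps from compound 2 replace the fluoro group with another group and also move the substituent on the phenyl ring, so the compounds shown cannot separate the identity of the group from where it sits. They also leave open how a methoxy group or a carboxylic acid on that phenyl ring would compare with the hydroxy group of compound 4 and the amino group of compound 3.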